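The source may hold more compounds than are shown below. What is called first, only, known or untested is meant among the compounds shown, and "the series" means these compounds.

Measured compounds and their values:
compound 1, `CC1=C(O)/C(=C/[C@H](C)CCC/C(C)=C/CC/C(C)=C/CCC2=CC(O)OC2=O)OC1=O` — > 100 ug/mL
compound 2, `COC(=O)C(C)(O)[C@](O)(C[C@H](C)CCC/C(C)=C/CC/C(C)=C/CCC1=CCN(CC(=O)O)C1=O)C(=O)OC` — > 100 ug/mL
compound 3, `CC1=C(O)/C(=C/[C@H](C)CC/C=C(/C)CC/C=C(/C)CCCC2=CC(=O)OC2O)OC1=O` — > 100 ug/mL

In a functional assay on K562 cells (Homo sapiens) for cytotoxicity, read by MTT assay (a higher number here means that more compound is tolerated, a lower number that less compound is tolerated), compound 1 gives > 100 ug/mL, which is a limit of the assay and not a measured number. In this assay compound 2 also gives only a limit, > 100 ug/mL. In this assay compound 3 likewise gives only a limit, > 100 ug/mL. Compound 1 therefore stands at the limit of > 100 ug/mL in this assay, at which 3 of the 3 values shown sit, and nothing in these three values sets one compound apart from another.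

The next compound, compound 4, `CC1=C(O)/C(=C/[C@H](C)CCC/C(C)=C/CC/C(C)=C/CCc2ccoc2)OC1=O`, differs from compound 1 in a single place: a group of 5 heavy atoms (4 carbon, 1 oxygen; one five-membered aromatic ring with 1 hetero atom) in place of a group of 7 heavy atoms (4 carbon, 3 oxygen; one five-membered non-aromatic ring with 1 hetero atom), on a saturated chain carbon, two bonds along the chain from a double-bonded chain carbon. The rest of the shared core is unchanged.

Going by the values given here, no two measured compounds differ in just one place, so no measured step shows how such a change shifts the read-out. Since all three measured compounds sit at the same limit, the change from compound 1 to compound 4 is expected to produce no step beyond the usual scatter; the expected step of a number no higher from compound 1 to compound 4 (the limit leaves the size open) is close to zero. For compound 4 the estimated value in this assay is 100 ug/mL, with a range from 50 ug/mL to 200 ug/mL, and the most likely outcome is that the assay again reports only a limit, because compound 1 gives > 100 ug/mL.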

Compound 4, concentration lethal to 50% of the cells: 39 ug/mL
Compound 4: middle estimate off by 2.6-fold (0.41 log units), on the high side; the whole stated range lies above it.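

In this assay, this position on the chain clearly affects the read-out: placing furan-3-yl on a saturated chain carbon, two bonds along the chain from a double-bonded chain carbon, in place of the five-membered non-aromatic ring of compound 1 gives an at least 2.5-fold lower number from compound 1 to compound 4 (0.40 log units; beyond the scatter). Compound 1 gives > 100 ug/mL, which is a limit of the assay and not a number, so the full size of this step cannot be known. Compound 4, at 39 ug/mL, is the only compound here with a measured number, and it alone stands apart from the others: the limit of > 100 ug/mL in this assay, at which 3 of the 4 values shown sit.

This single change alters several things at once, including the aromatic ring, the number of oxygen atoms and the hydrogen-bond donor count, so these compounds cannot show which of these differences matters. They also leave open whether a phenyl ring or an amine at this place, or a longer chain carrying the furan-3-yl, would give a similarly low number in this assay.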